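A few compounds are considered here, and "the series" means these few. Any claim that something is new, unique, unknown or untested is made for them only; others in the source may bear on it.

Compound 2 `Nc1ncc(-c2cnn(C3CCNCC3)c2)cc1-c1nc2ccc(Nc3ccc(F)cc3)cc2o1` and compound 1 `CN(c1ccccc1)c1ccc2oc(-c3cc(-c4cnn(C5CCNCC5)c4)cnc3N)nc2c1` were both examined in an assay on isolated protein for inhibition of G protein-coupled receptor kinase 5 (Homo sapiens), read by TR-FRET, with stated times of 10 min and 1 h; a lower number here means a stronger inhibitor, a higher number a weaker inhibitor. Compound 2 gives 3700 nM, the lower of the two numbers, while compound 1 gives 5050 nM; the two lie within the scatter of each other, so neither can be called the stronger inhibitor on this evidence. Compound 3 `Nc1ncc(-c2cnn(C3CCNCC3)c2)cc1-c1nc2ccc(NC(=O)Nc3ccccc3)cc2o1` has not yet been measured in this assay. It differs from compound 2 in one place: phenylcarbamoyl in place of 4-fluorophenyl on a nitrogen on an aromatic ring. For the measured compounds named here, no step between measured compounds bears on this change, so the expectation rests on compound 2 alone and carries little confidence. In this assay the step is estimated as a 1.5-fold lower number from compound 2 to compound 3 (0.17 log units; within the scatter), a small move toward a lower number that may well stay inside the scatter. Compound 3 is accordingly expected to give about 2500 nM in this assay, with a range from 700 nM to 9000 nM.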

Compound 3, half-maximal inhibitory concentration: 1660 nM
Compound 3: middle estimate off by 1.5-fold (0.18 log units), on the high side, within the range that was stated.
By their numbers in this assay, from the lowest: compound 3; then compounds 2 and 1 (each within the scatter of the next).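

For the compounds shown here, with phenylcarbamoyl in place of 4-fluorophenyl on a nitrogen on an aromatic ring, this assay shows a 2.2-fold lower number from compound 2 to compound 3 (0.35 log units; beyond the scatter), the only step available here and one that lies beyond the scatter. This position therefore responds to what it carries, and it accepts the larger phenylcarbamoyl group, which brings in a carbonyl and hydrogen-bond donor and acceptor atoms that 4-fluorophenyl lacks, while the fluorine is lost. No evidence here bears on why the number moves. The compounds shown leave open whether the carbonyl alone accounts for the step or the phenyl ring on it is also needed, a question that an acetyl group on this nitrogen would address. They also leave open whether a fluorine on the ring of the phenylcarbamoyl group would add to the step or take from it.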